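Changing the chain amine on a shared core

This account rests on a few compounds, and the source may have more. Where it says the series, first, only, none or still open, it means among the compounds named here.

Compound 1 `c1coc(CNc2nc(NCCCN3CCCC3)nc3ccccc23)c1` gives 35300 nM in a functional assay on DU-145 cells (Homo sapiens) for cytotoxicity, read by MTT assay, with a stated time of 2 days; a higher number here means a weaker inhibitor, a lower number a stronger inhibitor; compound 2 `CCCCCNc1nc(NCc2ccco2)c2cc(F)ccc2n1` gives 7240 nM; compound 3 `CN(C)CCCNc1nc(NCc2ccco2)c2ccccc2n1` gives 51000 nM.

Compound 3 has the highest number of the three; compound 1 lies nearest, within the scatter, and compound 2 furthest, beyond it. Compound 4 `CCN(CC)CCNc1nc(NCc2ccco2)c2ccccc2n1` differs from compound 3 in one place: diethylamino in place of (dimethylamino)methyl on a saturated chain carbon, two bonds along the chain from a nitrogen on an aromatic ring. Among the measured compounds shown here, the only measured step that also alters the chain amine is a 1.4-fold higher number from compound 1 to compound 3 (0.16 log units; within the scatter), which stayed within the scatter. Compound 2 differs from compound 3 in more than one place, so its value bears on this step only loosely. The step of a 1.0-fold lower number from compound 3 to compound 4 (0.01 log units; within the scatter) is therefore expected to stay within the scatter. For compound 4 the estimated value in this assay is 50000 nM, between 20000 nM and 120000 nM.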

Compound 4, half-maximal inhibitory concentration: > 100000 nM
Compound 4: a limit, no number; the forecaster's own chance of this, stated with the estimate: 10%; middle value at least 2.0-fold (0.30 log units) away from the limit.
By their numbers in this assay, from the lowest: compound 2; then compounds 1 and 3 (each within the scatter of the next). At a limit, above all of these: compound 4.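

In this assay compound 4 stands at a limit and not at a number: the limit of > 100000 nM in this assay, at which 1 of the 4 values shown sits.

Among changes to the chain amine, only an at least 2.8-fold higher number from compound 1 to compound 4 (0.45 log units; beyond the scatter) lies beyond the scatter, whereas a 1.4-fold higher number from compound 1 to compound 3 (0.16 log units; within the scatter) did not. The other step, an at least 1.9-fold higher number from compound 3 to compound 4 (0.29 log units; that floor lies within the scatter), has a floor that stays within the scatter, so this change at this place is not shown to differ from compound 3.

From the compounds shown here alone, what remains open is how far the true value of compound 4 lies past its limit. Also open, going by these compounds, is whether a 2-(dimethylamino)ethyl or a 3-(diethylamino)propyl chain would separate the chain length from the amine.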